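A few compounds are considered here, and "the series" means these few. Any claim that something is new, unique, unknown or untested is made for them only; others in the source may bear on it.

Going by the values given here, compound 3 `Oc1cccc(-c2cc(-c3ccccc3F)cc(-c3ccccc3O)n2)c1` is the one member of this small set with a number in a functional assay on HCT-15 cells (Homo sapiens) for inhibition; on this read-out higher numbers stand for weaker inhibition and lower numbers for stronger inhibition: compound 3 gives 8470 nM. Compound 1 `Oc1ccccc1-c1cc(-c2ccccc2F)cc(-c2ccccc2O)n1` stops at a limit of the assay, giving > 50000 nM. Compound 2 `Oc1ccccc1-c1cc(-c2cccc(F)c2)cc(-c2ccccc2O)n1` likewise stops at a limit, giving > 50000 nM. Among the compounds with values here, the only readable step is an at least 5.9-fold lower number from compound 1 to compound 3 (0.77 log units; beyond the scatter). Compound 4 `Oc1cccc(-c2cc(-c3cccc(F)c3)cc(-c3ccccc3O)n2)c1` differs from compound 3 by 3-fluorophenyl in place of 2-fluorophenyl on an aromatic carbon. From the compounds shown here alone, the same change was tried from compound 1 to compound 2, yet a step that the two limits leave unreadable from compound 1 to compound 2 because of the limit of > 50000 nM in this assay, at which 2 of the 3 values shown sit, so its size remains unknown. Without a readable precedent, compound 4 is expected to stay close to compound 3, with an expected step of a 1.0-fold higher number from compound 3 to compound 4 (0.00 log units; within the scatter). Compound 4 is therefore estimated at 8500 nM, between 3000 nM and 25000 nM.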

Compound 4, half-maximal inhibitory concentration: > 50000 nM
Compound 4: no number, only a limit (the forecaster's own chance of this, stated with the estimate: 15%); middle value at least 5.8-fold (0.76 log units) away from the limit.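

In this assay, 3-fluorophenyl in place of 2-fluorophenyl, at the position opposite the ring nitrogen, gives an at least 5.9-fold higher number from compound 3 to compound 4 (0.77 log units; beyond the scatter), so the position of the fluorine on this ring matters once the 3-hydroxyphenyl group is present. Among the compounds shown, a number appears only where 2-fluorophenyl and 3-hydroxyphenyl occur together, as in compound 3. The step from compound 2 to compound 4 cannot be read because both values are limits: the limit of > 50000 nM in this assay, at which 3 of the 4 values shown sit.

From the compounds shown here alone, whether a chlorine atom or a methoxy group in place of the fluorine would give a number remains open. So does the true size of the step to compound 4.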